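Ethoxy to propoxy on a lone measured compound

The source may hold more compounds than are shown below. What is called first, only, known or untested is meant among the compounds shown, and "the series" means these compounds.

In a functional assay on the whole organism (strain Sprague-Dawley) for inhibition, with Rattus norvegicus as the target, with a stated time of 10 min (on this read-out lower numbers stand for an effect already at smaller amounts and higher numbers for an effect only at larger amounts of compound), compound 1 (`CCOC(=O)c1cnc(-c2ccccc2[N+](=O)[O-])[nH]c1=O`) has the entry "not determined" (no result reported) and therefore offers no number. For the measured compounds named here, compound 2 (`CCOC(=O)c1cnc(-c2ccccc2OCC)[nH]c1=O`) gives 2 mg/kg in this assay as the only number available, so it cannot be ranked against another compound. Compound 3 (`CCCOc1ccccc1-c1ncc(C(=O)OCC)c(=O)[nH]1`) differs from compound 2 by one change, ethoxy to propoxy: methyl in place of hydrogen on a saturated chain carbon, two bonds along the chain from an oxygen on an aromatic ring. Going by the values given here, no measured step shows what this change does, so the expectation rests on compound 2 alone. In this assay the expected no change at the digits printed from compound 2 to compound 3 (within the scatter) stays within the scatter, with no direction favoured. The estimate for compound 3 is 2 mg/kg, with an expected range from 0.7 mg/kg to 6 mg/kg.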

Compound 3, dose for 50% inhibition: 5 mg/kg
Beside the measured number, compound 3's estimate is 2.5-fold (0.40 log units) below it, and the stated range covers the measured number.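

For the compounds shown here, in the whole-organism assay this assay, the step from ethoxy to propoxy gives the first measured reading at this position: a 2.5-fold higher number from compound 2 to compound 3 (0.40 log units; beyond the scatter). The added methyl on the saturated chain carbon is therefore not silent here, and the dose number moves upward, though this rests on a single pair of compounds. Nothing at hand gives a reason for this step.

On these data alone, whether a longer chain such as butoxy would raise the number further stays open. So does the reading for a shorter methoxy group or an amine at the same place.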